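Changing the Ring on a Sulfonyl Sulfur

The source may hold more compounds than are shown below. What is called first, only, known or untested is meant among the compounds shown, and "the series" means these compounds.

In a functional assay on A2780 cells (Homo sapiens) for cytotoxicity, read by sulforhodamine B assay, with a stated time of 72 h (on this read-out lower numbers stand for stronger inhibition and higher numbers for weaker inhibition), compound 1 `O=C(NCc1ccc(S(=O)(=O)c2cc(F)cc(F)c2)cc1)N1Cc2ccncc2C1` gives 6.3 nM, while compound 2 `O=C(NCc1ccc(S(=O)(=O)C2CCOCC2)cc1)N1Cc2ccncc2C1` gives 35 nM, the higher of these two numbers. Compound 3 `O=C(NCc1ccc(S(=O)(=O)C2CCN(C3COC3)CC2)cc1)N1Cc2ccncc2C1` carries 1-(oxetan-3-yl)piperidin-4-yl in place of oxan-4-yl on a sulfonyl sulfur. Among the measured compounds shown here, only one measured step changes the group at this place, a 5.6-fold higher number from compound 1 to compound 2 (0.74 log units; beyond the scatter), a modest change beyond the scatter. That step shows the group can matter, but it does not show which way the new group will move the number. No shift beyond the scatter is therefore expected in this assay, and the estimated step is a 1.2-fold lower number from compound 2 to compound 3 (0.07 log units; within the scatter). For compound 3 the estimated value is 30 nM, with an expected range of 9 nM to 100 nM.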

Compound 3, half-maximal inhibitory concentration: 7.4 nM
Compound 3: middle estimate off by 4.1-fold (0.61 log units), on the high side, outside the stated range (below it).
By their numbers in this assay, from the lowest: compounds 1 and 3 (each within the scatter of the next); then compound 2.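

In this assay the new group brings a 4.7-fold lower number from compound 2 to compound 3 (0.67 log units; beyond the scatter) and a 1.2-fold higher number from compound 1 to compound 3 (0.07 log units; within the scatter) so an aromatic ring on the sulfonyl sulfur is not needed for a number like that of compound 1. The two non-aromatic groups in compound 2 and compound 3 also give clearly different numbers, so the choice among such groups matters at this place. Nothing available here explains that difference. Going by these compounds, it remains open which part of the new group matters: a plain piperidin-4-yl, or one with a methyl group on its nitrogen, would separate the piperidine ring from the oxetane.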